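The source may report more compounds than this note shows. Statements on the series, on what has been measured and on what is new or still open speak of the compounds shown alone.

Values in an ADME assay on Vero 76 cells (Chlorocebus sabaeus) for cytotoxicity, read by crystal violet staining, with a stated time of 96 h; on this read-out lower numbers stand for higher toxicity in this test and higher numbers for lower toxicity in this test:
Compound 1 `CC(=O)NC(=S)Nc1cccc(C(F)(F)F)c1`: > 100000 nM, a limit of the assay.
Compound 2 `FC(F)(F)c1cccc(NC(=S)Nc2cccc(Br)c2)c1`: 14000 nM.
Compound 3 `Fc1ccccc1NC(=S)Nc1cccc(C(F)(F)F)c1`: 64000 nM.

Of the two values that are actual numbers, compound 3 has the higher, with a 4.6-fold higher number from compound 2 to compound 3 (0.66 log units; beyond the scatter). Compound 4 `FC(F)(F)c1cccc(NC(=S)NCc2ccco2)c1` differs from it as follows: (furan-2-yl)methyl in place of 2-fluorophenyl on an amide-type nitrogen. Among the measured compounds shown here, three measured steps concern this nitrogen. That step between compound 2 and compound 3 was modest. The other two, an at least 7.1-fold lower number from compound 1 to compound 2 (0.85 log units; beyond the scatter) and an at least 1.5-fold lower number from compound 1 to compound 3 (0.19 log units; that floor lies within the scatter), start from a limit, and only the first clears the scatter. The step expected here is a 1.3-fold lower number from compound 3 to compound 4 (0.11 log units; within the scatter), so no change beyond the scatter is expected, although a modest move in either direction remains possible. For compound 4 the estimated value is 50000 nM, with an expected range of 17000 nM to 100000 nM.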

Compound 4, half-maximal cytotoxic concentration: 50000 nM
Compound 4: middle estimate and measured number agree at the digits printed, within the range that was stated.
By their numbers in this assay, from the lowest: compound 2; then compounds 4 and 3 (each within the scatter of the next). At a limit, above all of these: compound 1.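

In this assay, (furan-2-yl)methyl in place of 2-fluorophenyl on this amide-type nitrogen, with its five-membered ring and hetero atom, brings no change beyond the scatter: a 1.3-fold lower number from compound 3 to compound 4 (0.11 log units; within the scatter). The separation from the 3-bromophenyl compound holds for this non-aryl substituent too, with a 3.6-fold higher number from compound 2 to compound 4 (0.55 log units; beyond the scatter), so compound 2 remains the low outlier among the numbered values. Compound 1 gives > 100000 nM, a limit. Its step, an at least 2.0-fold lower number from compound 1 to compound 4 (0.30 log units; that floor lies within the scatter), therefore cannot be read as a size: the limit of > 100000 nM in this assay, at which 1 of the 4 values shown sits.

Still open, as far as these compounds go, is what a longer alkyl chain or a chain ending in an amine would give on this nitrogen.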